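Second Bromo on the Naphthyl Ether: Expected Cytotoxicity

The source may hold more compounds than are shown below. What is called first, only, known or untested is meant among the compounds shown, and "the series" means these compounds.

Of the compounds shown here, two from this series have been tested in an ADME assay on MT4 cells (Homo sapiens) for cytotoxicity, read by MTT assay, with a stated time of 4 days; a lower number here means that less compound is tolerated, a higher number that more compound is tolerated. Compound 1 `CCNc1nc(Nc2ccc(C#N)cc2)nc(Oc2ccc3cc(Br)ccc3c2Br)n1` gives 74400 nM, and compound 2 `CNc1nc(Nc2ccc(C#N)cc2)nc(Oc2ccc3ccccc3c2Br)n1` gives 143000 nM. The two numbers lie within the usual scatter of each other, so neither compound can be called better tolerated than the other.

Compound 3 `CNc1nc(Nc2ccc(C#N)cc2)nc(Oc2ccc3cc(Br)ccc3c2Br)n1` has not yet been measured. It differs from compound 2 in one place: bromo in place of hydrogen on an aromatic carbon. Among the compounds with values here, no measured pair in this set isolates exactly this change, so the expectation rests on compound 1, which carries the same second bromo and gives 74400 nM in this assay. On that basis the step from compound 2 to compound 3 is expected to be small, a modest shift toward less compound tolerated, of size a 1.7-fold lower number from compound 2 to compound 3 (0.23 log units; within the scatter), which stays within the scatter. Compound 3 is therefore estimated at 85000 nM, within a range from 40000 nM to 180000 nM.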

Compound 3, half-maximal cytotoxic concentration: 92800 nM
Beside the measured number, compound 3's estimate is 1.1-fold (0.04 log units) below it; the measured number falls inside the stated range.
By their numbers in this assay, from the lowest: compounds 1, 3 and 2 (each within the scatter of the next).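

In this assay, the direct step for bromo in place of hydrogen on this aromatic carbon is a 1.5-fold lower number from compound 2 to compound 3 (0.19 log units; within the scatter), so this change at this position cannot be told apart from repeat-measurement scatter. A second single change, hydrogen in place of methyl on a saturated chain carbon bound to a nitrogen on an aromatic ring, gives a 1.2-fold higher number from compound 1 to compound 3 (0.10 log units; within the scatter) and also cannot be told apart from scatter. No supporting measurement here offers an explanation for either step.

The compounds shown leave open whether a different group on this aromatic carbon, such as an amine or a carboxylic acid, would give a step beyond the scatter. They also leave open whether a longer chain on that nitrogen would do so.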